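From Ethyl to Methyl at the Limit

The source may report more compounds than this note shows. Statements on the series, on what has been measured and on what is new or still open speak of the compounds shown alone.

Of the compounds shown here, three with a shared core have been tested in a functional assay on Ramos cells (Homo sapiens) for antiproliferative activity, read by CCK-8 assay, with a stated time of 48 h (a lower number here means a stronger inhibitor, a higher number a weaker inhibitor), so far. Compound 1 (`C=CC(=O)Nc1cccc(-n2cnc3cnc(Nc4ccc(OC)cc4)nc32)c1`) gives > 40000 nM, which is a limit of the assay and not a number. Compound 3 (`C=CC(=O)Nc1cccc(-n2cnc3cnc(Nc4ccc(N5CCN(C(C)=O)C(C)C5)cc4)nc32)c1`) gives > 40000 nM, which is likewise a limit. Compound 2 (`C=CC(=O)Nc1cccc(-n2cnc3cnc(Nc4ccc(N5CCN(CC)CC5)cc4OC)nc32)c1`) gives > 40000 nM, again a limit. Compound 2 therefore has no readable value, and the whole set rests on (the limit of > 40000 nM in this assay, at which 3 of the 3 values shown sit).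

Compound 4 (`C=CC(=O)Nc1cccc(-n2cnc3cnc(Nc4ccc(N5CCN(C)CC5)cc4OC)nc32)c1`) differs from compound 2 in one place: hydrogen in place of methyl on a saturated chain carbon bound to an amine nitrogen in a ring. This is hydrogen in place of methyl on a saturated chain carbon bound to an amine nitrogen in a ring, so that 4-ethylpiperazin-1-yl becomes 4-methylpiperazin-1-yl.

Among the measured compounds shown here, the only measured step is a step that the two limits leave unreadable from compound 1 to compound 3, where 4-acetyl-3-methylpiperazin-1-yl stands in place of methoxy on an aromatic carbon. For the measured compounds named here, it offers no size to carry over, and no measured step touches this ethyl group. No change beyond the usual scatter is therefore expected in this assay, and compound 4 will probably also be reported only as a limit. The expected change is a number no higher from compound 2 to compound 4 (the limit leaves the size open) as an estimate. For compound 4 the estimated value is 40000 nM, with an expected range from 15000 nM to 80000 nM.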

Compound 4, half-maximal inhibitory concentration: 13200 nM
Beside the measured number, compound 4's estimate is 3.0-fold (0.48 log units) above it; measured number outside the range, below it.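

In this assay, the group on the amine nitrogen in the ring proves to be a place where a small change can be read: replacing 4-ethylpiperazin-1-yl with 4-methylpiperazin-1-yl, a loss of a single carbon, gives an at least 3.0-fold lower number from compound 2 to compound 4 (0.48 log units; beyond the scatter). Compound 4 is the only compound shown with a true number, so this position provides the one measured foothold in the set, and the change lies beyond the usual scatter. The full size of the step stays open, the step from compound 1 to compound 3 cannot be read, and every other compound still stands at a limit: the limit of > 40000 nM in this assay, at which 3 of the 4 values shown sit.

The compounds shown leave open whether the number keeps falling with a bare hydrogen on that ring nitrogen, or whether a hydroxyethyl group or an acetyl group there would give a readable value at all. They also leave open how much the methoxy group on the aromatic ring contributes to the value of compound 4, since no pair shown isolates that group with the 4-methylpiperazin-1-yl in place.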